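The source may hold more compounds than are shown below. What is called first, only, known or untested is meant among the compounds shown, and "the series" means these compounds.

Measured so far in a functional assay on HCT-116 cells (Homo sapiens), read by MTT assay, with a stated time of 72 h; on this read-out lower numbers stand for stronger inhibition and higher numbers for weaker inhibition:

compound 1 `C#Cc1cn([C@@H]2O[C@H](CO)[C@@H](O)[C@H]2O)c2ncnc(C)c12`: > 20000 nM
compound 2 `C#Cc1cn([C@@H]2O[C@H](CO)[C@@H](O)[C@H]2O)c2ncnc(NC)c12`: > 20000 nM
compound 3 `CNc1ncnc2c1c(-c1ccsc1)cn2[C@@H]1O[C@H](CO)[C@@H](O)[C@H]1O`: > 20000 nM

The value of compound 1 is a limit of this assay, not a number. The value of compound 2 is likewise a limit. The value of compound 3 is likewise a limit. All three sit at the limit of > 20000 nM in this assay, at which 3 of the 3 values shown sit.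

Compound 2 and compound 1 differ in one place:
methyl in place of methylamino on an aromatic carbon
The step is a step that the two limits leave unreadable from compound 2 to compound 1.

The cores of compound 2 and compound 3 differ as follows:
thiophen-3-yl in place of ethynyl on an aromatic carbon
The step is a step that the two limits leave unreadable from compound 2 to compound 3.

Compound 4 `Cc1ncnc2c1c(-c1ccsc1)cn2[C@@H]1O[C@H](CO)[C@@H](O)[C@H]1O` has not yet been measured in this assay. It differs from compound 3 as follows:
methyl in place of methylamino on an aromatic carbon
The place lines of this change and of the change from compound 2 to compound 1 agree word for word, so it is the same change, made on the core of compound 3 instead of on the core of compound 2.

Because a step that the two limits leave unreadable from compound 2 to compound 1 has no readable size, the same change gives no guide to a number for compound 4. Because the limit of > 20000 nM in this assay, at which 3 of the 3 values shown sit, holds every value shown, the expected step is a step that the limit leaves unreadable from compound 3 to compound 4, meaning no movement away from that limit. Compound 4 is expected to give 30000 nM in this assay. The estimated range for compound 4 runs from 12000 nM to 100000 nM, with the most likely outcome being that the assay again reports only a limit.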

Compound 4, half-maximal inhibitory concentration: 1430 nM
Compound 4: middle estimate off by 21-fold (1.32 log units), on the high side; the measured number lies below the stated range.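

In this assay, methyl in place of methylamino with thiophen-3-yl kept gives an at least 13-fold lower number from compound 3 to compound 4 (1.14 log units; beyond the scatter), and thiophen-3-yl in place of ethynyl with methyl kept gives an at least 13-fold lower number from compound 1 to compound 4 (1.14 log units; beyond the scatter). Compound 1 gives > 20000 nM, which is a limit and not a number. The same methyl change on the core of compound 2 cannot be read, and neither can the thiophen-3-yl change with methylamino kept, so the data show a large step for the methyl change on one core and show neither that it carries over to another core nor that it fails to: the limit of > 20000 nM in this assay, at which 3 of the 4 values shown sit.

Among these four compounds, a measured number appears only where methyl and thiophen-3-yl occur together, but it remains open whether thiophen-3-yl is specifically required or whether another group in that place, such as phenyl, would serve as well. On these data alone, it is also open whether a plain amino group or an ethyl chain in place of methyl would give a measured number, and the true sizes of the steps among the compounds held at the limit remain unknown.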